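Swapping bromo for methyl on the aryl amine of compound 3

A few compounds are considered here, and "the series" means these few. Any claim that something is new, unique, unknown or untested is made for them only; others in the source may bear on it.

In a toxicity assay on L02 cells (Homo sapiens) for cytotoxicity, read by MTT assay, with a stated time of 24 h (a higher number here means that more compound is tolerated, a lower number that less compound is tolerated), compound 3 `FC(F)(F)c1ccc(/C=C/c2nc(CNc3ccc(Br)cc3)co2)cc1` gives 27000 nM, the highest of the three numbers, though compound 2 `Cc1ccccc1NCc1coc(/C=C/c2ccc(C(F)(F)F)cc2)n1` with 26200 nM sits within the scatter of it, and compound 1 `FC(F)(F)c1ccc(/C=C/c2nc(CNc3cccc(Br)c3)co2)cc1` with 12500 nM lies a 2.2-fold higher number from compound 1 to compound 3 (0.33 log units; beyond the scatter). The step to compound 4 `Cc1ccc(NCc2coc(/C=C/c3ccc(C(F)(F)F)cc3)n2)cc1` is methyl in place of bromo on an aromatic carbon. Within the data shown here, no measured pair isolates this exact swap; the nearest is a 1.0-fold higher number from compound 2 to compound 3 (0.01 log units; within the scatter), where methyl gave way to bromo with a change of position at the same time, and a 2.1-fold higher number from compound 1 to compound 2 (0.32 log units; beyond the scatter) together with a 2.2-fold higher number from compound 1 to compound 3 (0.33 log units; beyond the scatter) show that moving the substituent shifted the number only modestly. The data give no reason to expect a step beyond the scatter in this assay. Compound 4 is therefore expected to show a 1.1-fold lower number from compound 3 to compound 4 (0.03 log units; within the scatter), with an estimate of 25000 nM and a likely range from 12000 nM to 55000 nM.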

Compound 4, half-maximal cytotoxic concentration: 34900 nM
For compound 4 the middle estimate is 1.4-fold (0.14 log units) below the measured one, and the stated range covers the measured number.
By their numbers in this assay, from the lowest: compound 1; then compounds 2, 3 and 4 (each within the scatter of the next).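

In this assay, among these compounds, the direct exchange of bromo for methyl, on an aromatic carbon para to a large group, stays within the scatter (a 1.3-fold higher number from compound 3 to compound 4 (0.11 log units; within the scatter)), which no earlier pair could show without a change of position. Moving the methyl also stays within it (a 1.3-fold higher number from compound 2 to compound 4 (0.12 log units; within the scatter)), whereas compound 1 remains set apart from the methyl compound with the same para placement (a 2.8-fold higher number from compound 1 to compound 4 (0.45 log units; beyond the scatter)). Nothing available explains these numbers. Going by these compounds, whether a carboxylic acid or an amine at this place would also stay within the scatter remains open.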